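The source may report more compounds than this note shows. Statements on the series, on what has been measured and on what is new or still open speak of the compounds shown alone.

Compound 1 `COc1cccc(CNCCCNc2ccnc3cc(-c4ccc(C(C)(C)C)cc4)ccc23)c1O` gives 9.47 in a physicochemical assay for acid dissociation. Compound 2 `CC(C)(C)c1ccc(-c2ccc3c(NCCCNCc4ccco4)ccnc3c2)cc1` gives 9.47. Compound 3 `COc1ccccc1Oc1ccc2c(NCCCNCc3ccco3)ccnc2c1` gives 9.28.

On these numbers compound 1 stands level with compound 2, the two together the highest of the three; compound 3 sits a number 0.19 log units lower from compound 2 to compound 3 (within the scatter), which stays within the scatter. The step of no change at the digits printed from compound 1 to compound 2 (within the scatter) shows the same: an exchange far from the measured proton left the read-out unmoved.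

Compound 4 `COc1cccc(CNCCCNc2ccnc3cc(CC(C)C)ccc23)c1O` differs from compound 1 by isobutyl in place of 4-(tert-butyl)phenyl on an aromatic carbon. The step from compound 2 to compound 3 bears on this, since there too the 4-(tert-butyl)phenyl on an aromatic carbon was exchanged, and it gave a number 0.19 log units lower from compound 2 to compound 3 (within the scatter). No step beyond the scatter is therefore expected in this assay for compound 4; the estimate is 9.45 (9.15 to 9.75), a change of a number 0.02 log units lower from compound 1 to compound 4 (within the scatter).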

Compound 4, acid dissociation constant: 9.47
For compound 4 the middle estimate is 0.02 log units below the measured one; the range from low to high includes it.
By their numbers in this assay, from the lowest: compounds 3, 1, 2 and 4 (each within the scatter of the next).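

In this assay, isobutyl in place of 4-(tert-butyl)phenyl on an aromatic carbon gives no change at the digits printed from compound 1 to compound 4 (within the scatter). The earlier exchange at this position was made with furan-2-yl on the chain; here the 2-hydroxy-3-methoxyphenyl group stays, and a group with no ring and 4 heavy atoms replaces one with a six-membered aromatic ring and 10 heavy atoms without moving the read-out. No measurement on hand offers an explanation for this. Open, on these data alone, is whether an amine or a carboxylic acid on this aromatic carbon would also leave the read-out unmoved.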